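This account rests on a few compounds, and the source may have more. Where it says the series, first, only, none or still open, it means among the compounds named here.

Three compounds have been measured in a functional assay on MT4 cells (Homo sapiens); a higher number here means that more compound is tolerated, a lower number that less compound is tolerated:

Compound 1, `CC(=O)NC1=CS(=O)(=O)O[C@@]12[C@@H](CO[Si](C)(C)C(C)(C)C)O[C@@H](n1cc(C)c(=O)n(C)c1=O)[C@@H]2O[Si](C)(C)C(C)(C)C`, gives 10700 nM.
Compound 2, `COC(=O)CNC1=CS(=O)(=O)O[C@@]12[C@@H](CO[Si](C)(C)C(C)(C)C)O[C@@H](n1cc(C)c(=O)n(C)c1=O)[C@@H]2O[Si](C)(C)C(C)(C)C`, gives 105000 nM.
Compound 3, `Cc1cn([C@@H]2O[C@H](CO[Si](C)(C)C(C)(C)C)[C@@]3(OS(=O)(=O)C=C3NCC(=O)C(N)=O)[C@H]2O[Si](C)(C)C(C)(C)C)c(=O)n(C)c1=O`, gives 9590 nM.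

Compound 1 stands second highest of the three. Its nearest neighbour is compound 3, and the two lie within the scatter of each other, as a 1.1-fold lower number from compound 1 to compound 3 (0.05 log units; within the scatter) shows. Its furthest neighbour is compound 2, reached by a 9.8-fold higher number from compound 1 to compound 2 (0.99 log units; beyond the scatter). Between the other two, an 11-fold lower number from compound 2 to compound 3 (1.04 log units; beyond the scatter) is the largest step in the set.

Compound 4, `COC(=O)CCNC1=CS(=O)(=O)O[C@@]12[C@@H](CO[Si](C)(C)C(C)(C)C)O[C@@H](n1cc(C)c(=O)n(C)c1=O)[C@@H]2O[Si](C)(C)C(C)(C)C`, has not yet been measured. It differs from compound 1 in one place: 2-(methoxycarbonyl)ethyl in place of acetyl on an amine nitrogen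

Going by the values given here, the steps that bear on this change are those that replace the same acetyl on compound 1. Replacement by (methoxycarbonyl)methyl gave a 9.8-fold higher number from compound 1 to compound 2 (0.99 log units; beyond the scatter), whereas replacement by (carbamoylcarbonyl)methyl gave a 1.1-fold lower number from compound 1 to compound 3 (0.05 log units; within the scatter). The group entering compound 4, 2-(methoxycarbonyl)ethyl, again carries a methoxycarbonyl, so the step toward compound 2 is the better guide, though the extra chain length leaves room for doubt. Compound 4 is therefore expected to show a higher number, roughly a 5.6-fold higher number from compound 1 to compound 4 (0.75 log units; beyond the scatter), in this assay. The estimate for compound 4 is 60000 nM, in the range 15000 nM to 200000 nM.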

Compound 4, half-maximal cytotoxic concentration: > 250000 nM
Compound 4 ended at the assay's limit; the forecaster's own chance of this, stated with the estimate: 15%; middle value at least 4.1-fold (0.61 log units) away from the limit.
By their numbers in this assay, from the lowest: compounds 3 and 1 (each within the scatter of the next); then compound 2. At a limit, above all of these: compound 4.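

In this assay compound 4 gives > 250000 nM, which is a limit of the assay and not a number: the limit of > 250000 nM in this assay, at which 1 of the 4 values shown sits. Even so, 2-(methoxycarbonyl)ethyl on this amine nitrogen moves the number further than any earlier replacement of acetyl, with an at least 23-fold higher number from compound 1 to compound 4 (1.36 log units; beyond the scatter), and the gap to the carbamoylcarbonyl-bearing chain is also wide, with an at least 26-fold higher number from compound 3 to compound 4 (1.41 log units; beyond the scatter). Chain length at this nitrogen therefore matters in its own right, as the two esters show with an at least 2.3-fold higher number from compound 2 to compound 4 (0.37 log units; beyond the scatter), so the rise seen with the shorter (methoxycarbonyl)methyl chain does not end there.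

The compounds shown leave open how far compound 4 lies past the limit, so the true size of these steps stays unknown. They also leave open whether a longer chain, or a carboxylic acid in place of the methoxycarbonyl, would keep the number this high.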